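Nitro in place of trifluoromethyl on a weak inhibitor

The source may hold more compounds than are shown below. What is called first, only, known or untested is meant among the compounds shown, and "the series" means these compounds.

Compound 1 `Nc1nc2cc(Cl)c(Cl)cc2n1Cc1cccc([N+](=O)[O-])c1` gives 65000 nM
Compound 2 `FC(F)(F)c1cccc(Cn2c(Cl)nc3cc(Cl)c(Cl)cc32)c1` gives > 100000 nM (a limit)

Both readings come from a functional assay on KB cells (Homo sapiens) for inhibition (on this read-out lower numbers stand for stronger inhibition and higher numbers for weaker inhibition), and are the only ones available so far. Compound 2 stands with > 100000 nM as its reading, which is a limit of the assay and not a number. Compound 3 `O=[N+]([O-])c1cccc(Cn2c(Cl)nc3cc(Cl)c(Cl)cc32)c1` differs from compound 2 in one place, with nitro in place of trifluoromethyl on an aromatic carbon and the rest of the structure unchanged. Among the compounds with values here, no measured pair shows what this exchange does, so the expectation rests on little. Compound 1, which also bears a nitro group, gives 65000 nM as a measured number in this assay and so offers the only nearby reference. A small step toward stronger inhibition is expected, or none beyond the scatter, and the estimated step is an at least 1.2-fold lower number from compound 2 to compound 3 (0.09 log units; that floor lies within the scatter) in this read-out. Compound 3 is estimated at 80000 nM with an expected range from 30000 nM to 200000 nM and a fair chance of only a limit.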

Compound 3, half-maximal inhibitory concentration: 239000 nM
Estimate against measurement, compound 3: 3.0-fold (0.48 log units) below, outside the stated range (above it).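

In this assay, within the data shown here, with the nitro group held constant, chloro in place of amino on an aromatic carbon gives a 3.7-fold higher number from compound 1 to compound 3 (0.57 log units; beyond the scatter), the first step in this set that can be read, and it places compound 3 as the weaker inhibitor of this pair. Compound 2 stands at > 100000 nM, which is a limit of the assay and not a number. The step for nitro in place of trifluoromethyl therefore cannot be read, and its size stays unknown, because compound 2 has only that limit: the limit of > 100000 nM in this assay, at which 1 of the 3 values shown sits.

The compounds shown leave open whether amino in place of chloro gives a step of similar size when trifluoromethyl rather than nitro sits on the aromatic ring, and what the exchange of these two groups is worth when both partners carry a measured number. They also leave open how a nitrile or a methoxy group on that same aromatic carbon would read in this assay, with either amino or chloro on the shared core.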